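The source may report more compounds than this note shows. Statements on the series, on what has been measured and on what is new or still open speak of the compounds shown alone.

Series notes. Compound 1 `CCC(C)(C)Cc1c[nH]c(CCc2ccc(-c3cccc(C)n3)cc2)n1` gives 105 nM in a functional assay on HEK293 cells for agonist activity at Bombesin receptor subtype-3 (Homo sapiens), read by luminescence and calcium flux, with a stated time of 10 min; on this read-out lower numbers stand for an effect already at smaller amounts and higher numbers for an effect only at larger amounts of compound. Compound 2 `CCC(C)(C)Cc1c[nH]c(CCc2ccc(-n3ncnn3)cc2)n1` gives 422 nM in this assay, and compound 3 `CCC(C)(C)Cc1c[nH]c(CCc2ccc(-c3cccc(C#N)n3)cc2)n1` gives 193 nM in this assay. Compound 3 thus stands second highest of the three numbers: the step of a 1.8-fold higher number from compound 1 to compound 3 (0.26 log units; within the scatter) lies within the scatter, whereas the step of a 2.2-fold lower number from compound 2 to compound 3 (0.34 log units; beyond the scatter) lies beyond it. Compound 4 `CCC(C)(C)Cc1c[nH]c(CCc2ccc(-c3cccc(N)n3)cc2)n1` differs from compound 3 by amino in place of cyano on an aromatic carbon. Within the data shown here, the only measured step touching this same place, a 1.8-fold higher number from compound 1 to compound 3 (0.26 log units; within the scatter), stayed within the scatter; no measured step involving an amino group exists in the set. Compound 4 is therefore expected to show no step beyond the scatter in this assay, the expected step being a 1.2-fold lower number from compound 3 to compound 4 (0.08 log units; within the scatter). The estimate for compound 4 is 160 nM, within a range from 50 nM to 500 nM.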

Compound 4, half-maximal effective concentration: 37 nM
The estimate for compound 4 lay 4.3-fold (0.64 log units) above the measured number; the whole stated range lies above it.
By their numbers in this assay, from the lowest: compound 4; then compounds 1 and 3 (each within the scatter of the next); then compound 2.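

The position next to the ring nitrogen, where the change from methyl to cyano stayed within the scatter, proves sensitive in this assay: amino gives a 5.2-fold lower number from compound 3 to compound 4 (0.72 log units; beyond the scatter) against cyano and a 2.8-fold lower number from compound 1 to compound 4 (0.45 log units; beyond the scatter) against methyl. Taking 6-aminopyridin-2-yl in place of 2H-tetrazol-2-yl gives an 11-fold lower number from compound 2 to compound 4 (1.06 log units; beyond the scatter) and this is the largest step in the series. No evidence at hand explains why amino stands apart from methyl and cyano here.

On these data alone, whether the free amino group itself is required stays open. A methylamino, dimethylamino or hydroxyl group at this place would test that.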